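Stereochemical inversion and metabolic stability: compound 3 to compound 4

The source may report more compounds than this note shows. Statements on the series, on what has been measured and on what is new or still open speak of the compounds shown alone.

Measured in an ADME assay (liver) for metabolic stability, with Liver microsome (Homo sapiens) as the target, using microsomes, with a stated time of 30 min; a lower number here means that less of the compound is left, a higher number that more of the compound is left:
compound 1 `COC(=O)N[C@H](C(=O)N1CCC[C@H]1C(=O)Nc1ccc([C@H]2CC[C@H](c3ccc(NC(=O)[C@@H]4CCCN4C(=O)[C@@H](NC(=O)OC)C(C)C)cc3)N2c2ccc(C(F)(F)F)cc2)cc1)C(C)C`: 58%
compound 2 `COC(=O)N[C@H](C(=O)N1CCC[C@H]1C(=O)Nc1ccc([C@H]2CC[C@H](c3ccc(NC(=O)[C@@H]4CCCN4C(=O)[C@@H](NC(=O)OC)C(C)(C)C)cc3)N2c2ccc(F)cc2)cc1)C(C)(C)C`: 54%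
compound 3 `COC(=O)N[C@H](C(=O)N1CCC[C@H]1C(=O)Nc1ccc([C@@H]2CC[C@@H](c3ccc(NC(=O)[C@@H]4CCCN4C(=O)[C@@H](NC(=O)OC)[C@@H](C)OC)cc3)N2c2ccc(F)cc2)cc1)[C@@H](C)OC`: 54%

Compound 3 stands level with compound 2 at the digits shown, the two together the lowest of the three numbers; compound 1 lies a little higher, but within the scatter of repeated runs, so the three values do not separate.

Compound 4 `COC(=O)N[C@H](C(=O)N1CCC[C@H]1C(=O)Nc1ccc([C@H]2CC[C@H](c3ccc(NC(=O)[C@@H]4CCCN4C(=O)[C@@H](NC(=O)OC)[C@@H](C)OC)cc3)N2c2ccc(F)cc2)cc1)[C@@H](C)OC` has the same atoms and bonds as compound 3; (the two compounds have the same atoms and bonds and differ only in configuration as drawn: 2 of 8 stereo elements differ; a stereocentre at a saturated ring carbon is drawn S in compound 3 and R in compound 4; a stereocentre at a saturated ring carbon is drawn S in compound 3 and R in compound 4). For the measured compounds named here, no pair among the measured compounds differs in configuration alone, so nothing in the set gives the size of such a step. In this assay no step beyond the scatter is expected in either direction.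

For compound 4 the estimate is 54%, within 40% to 68%, which means an expected step of no change at the digits printed from compound 3 to compound 4 (within the scatter).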

Compound 4, percent of the compound remaining: 48%
Compound 4: the middle estimate sits 6 percentage points above what was measured; the measured number falls inside the stated range.
By their numbers in this assay, from the lowest: compounds 4, 2, 3 and 1 (each within the scatter of the next).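

In this assay the configuration change at the two saturated ring carbons gives a number 6 percentage points lower from compound 3 to compound 4 (within the scatter). This is the first measure in the series of a change in configuration alone, and at this position it does not separate the two compounds: the fact that compounds 3 and 4 differ only in the configuration as drawn

For the compounds shown here, still open is whether a change at only one of these ring carbons would read the same way. Also open, on these data alone, is whether the same change would hold with an amine or a carboxylic acid in place of the fluorine.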